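Swapping the Indole Halogen in a Somatostatin Receptor Ligand

The source may report more compounds than this note shows. Statements on the series, on what has been measured and on what is new or still open speak of the compounds shown alone.

Of the compounds shown here, two have been measured in an assay on isolated protein for inhibition of somatostatin receptor type 2 (Homo sapiens), tested at 10 uM; on this read-out higher numbers stand for weaker inhibition and lower numbers for stronger inhibition. Compound 1, `NCCCn1c(SCCc2c[nH]c3ccccc23)nnc1-c1ccc2ccccc2c1`, gives 640 nM. Compound 2, `NCCCCn1c(SCCc2c[nH]c3cc(F)ccc23)nnc1-c1ccc2ccccc2n1`, gives 2.7 nM in this assay, the lowest of the two numbers; compound 1 sits far above it, and that gap lies well beyond the usual scatter. Compound 3, `NCCCCn1c(SCCc2c[nH]c3ccc(Cl)cc23)nnc1-c1ccc2ccccc2n1`, has not yet been measured. It differs from compound 2 in one place: 5-chloro-1H-indol-3-yl in place of 6-fluoro-1H-indol-3-yl on a saturated chain carbon, two bonds along the chain from a sulfur. Going by the values given here, no pair of measured compounds differs only in this place, so the size of such a step has no direct precedent among the numbers here. Only the kind of halogen and its position on the indole change, and the step from compound 2 to compound 3 is expected to be a 1.9-fold higher number from compound 2 to compound 3 (0.27 log units; within the scatter), at most a mild weakening, close to the scatter. Compound 3 is therefore estimated at 5 nM, in a range from 1.5 nM to 20 nM.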

Compound 3, inhibition constant: 5.6 nM
Compound 3: middle estimate off by 1.1-fold (0.05 log units), on the low side, and the stated range covers the measured number.
By their numbers in this assay, from the lowest: compound 2; then compound 3; then compound 1.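

Going by these compounds alone, this is the first pair here that differs in one place only: in this assay, 5-chloro-1H-indol-3-yl in place of 6-fluoro-1H-indol-3-yl gives a 2.1-fold higher number from compound 2 to compound 3 (0.32 log units; beyond the scatter), a modest step. The kind of halogen and its position on the indole change together, so the pair shows that the combined change weakens inhibition only modestly here, but it cannot show how much each part contributes. Nothing measured here explains the size of this step.

A 6-chloro-1H-indol-3-yl or 5-fluoro-1H-indol-3-yl group would separate the halogen from its position. As far as these compounds go, it also remains open whether a bromine or a methoxy group on the indole would keep the number close to those of compound 2 and compound 3.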